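The source may hold more compounds than are shown below. What is called first, only, known or untested is meant among the compounds shown, and "the series" means these compounds.

Values in an ADME assay on the whole organism (Mus musculus, strain ICR) for metabolic stability, read by LC-MS, with a stated time of 24 h, at a dose of 50 mg/kg by the oral route; on this read-out higher numbers stand for a longer-lived compound and lower numbers for a shorter-lived compound:
- compound 1 `Cc1nc(N[C@H](C)c2cccc(C(F)F)c2F)c2cc3c(cc2n1)OCC[C@H]1CN(C(=O)C2COC2)CCN31`: 1.36 h
- compound 2 `Cc1nc(N[C@H](C)c2cccc(C(F)F)c2F)c2cc3c(cc2n1)OCC[C@H]1CN(C(=O)c2cccnc2)CCN31`: 1.47 h
- compound 3 `Cc1nc(N[C@H](C)c2cccc(C(F)F)c2F)c2cc3c(cc2n1)OCC[C@H]1CN(C)CCN31`: 20 h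

Compound 3 stands highest of the three, with compound 3 at 20 h. The next compound is compound 4 `Cc1nc(N[C@H](C)c2cccc(C(F)F)c2F)c2cc3c(cc2n1)OCC[C@H]1CN(CC2COC2)CCN31`, not yet measured. The change is oxetan-3-yl in place of hydrogen on a saturated chain carbon bound to an amine nitrogen in a ring, so methyl becomes (oxetan-3-yl)methyl.

Two large steps bear on this nitrogen: a 15-fold higher number from compound 1 to compound 3 (1.17 log units; beyond the scatter) and a 14-fold higher number from compound 2 to compound 3 (1.13 log units; beyond the scatter). Between the two carbonyl compounds, the result is a 1.1-fold higher number from compound 1 to compound 2 (0.03 log units; within the scatter), within the scatter. Like compound 3, compound 4 has no carbonyl on that nitrogen, which argues against a fall of that size. However, no measured step tests growth on the methyl carbon. The oxetan-3-yl group also occurs in compound 1, which gives 1.36 h, so a moderate fall is expected rather than none.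

The expected change is a 2.9-fold lower number from compound 3 to compound 4 (0.46 log units; beyond the scatter). For compound 4 the estimate is 7 h, with an expected range from 2 h to 24 h.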

Compound 4, half-life: 7.39 h
Compound 4: the middle estimate sits 1.1-fold (0.02 log units) below what was measured, within the range that was stated.
By their numbers in this assay, from the lowest: compounds 1 and 2 (each within the scatter of the next); then compound 4; then compound 3.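

In this assay, oxetan-3-yl in place of hydrogen on a saturated chain carbon bound to an amine nitrogen in a ring gives a 2.7-fold lower number from compound 3 to compound 4 (0.43 log units; beyond the scatter), so growth at this carbon lowers the half-life but keeps it clear of both carbonyl compounds. With the oxetan-3-yl group kept, (oxetan-3-yl)methyl in place of (oxetan-3-yl)carbonyl gives a 5.4-fold higher number from compound 1 to compound 4 (0.74 log units; beyond the scatter), and in place of (pyridin-3-yl)carbonyl it gives a 5.0-fold higher number from compound 2 to compound 4 (0.70 log units; beyond the scatter), which shows that the presence of oxetan-3-yl alone does not set the short half-life of compound 1. No measurement offered here explains these differences.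

The compounds shown leave open whether an ethyl group or a longer chain on this nitrogen would lower the half-life as far. They also leave open how a cyclopropyl ring would compare with oxetan-3-yl on the same carbon.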